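The compounds below may be only part of what the source reports. "The series", "measured", "known", "first", "only" and "open" are said of these compounds alone.

In a functional assay on HepG2 cells (Homo sapiens) for antiproliferative activity, read by sulforhodamine B assay, with a stated time of 72 h (on this read-out higher numbers stand for weaker inhibition and lower numbers for stronger inhibition), compound 1 (`CC(C)[C@@H](NC(=O)OC(C)(C)C)C(=O)Nc1ccc2ncnc(Nc3cccc(Br)c3)c2c1`) gives > 50000 nM, which is a limit and not a number. Compound 2 (`CC(C)[C@@H](NC(=O)OC(C)(C)C)C(=O)Nc1ccc2ncnc(Nc3ccc(F)c(Cl)c3)c2c1`) gives > 50000 nM, also a limit. Compound 3 (`CC(C)[C@@H](NC(=O)OC(C)(C)C)C(=O)Nc1ccc2ncnc(Nc3cccc(C(F)(F)F)c3)c2c1`) gives a measured 4300 nM. Compound 1 thus stands at the limit of > 50000 nM in this assay, at which 2 of the 3 values shown sit.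

Compound 4 (`CC[C@H](C)[C@@H](NC(=O)OC(C)(C)C)C(=O)Nc1ccc2ncnc(Nc3cccc(Br)c3)c2c1`) differs from compound 1 in one place: methyl in place of hydrogen on a saturated chain carbon, three bonds along the chain from an amide-type nitrogen and a carbonyl carbon. This is methyl in place of hydrogen on a saturated chain carbon, three bonds along the chain from an amide-type nitrogen and a carbonyl carbon, so isopropyl becomes sec-butyl.

The measured steps all lie elsewhere. There is an at least 11-fold lower number from compound 1 to compound 3 (1.06 log units; beyond the scatter), and there is an at least 11-fold lower number from compound 2 to compound 3 (1.06 log units; beyond the scatter), while a step that the two limits leave unreadable from compound 1 to compound 2 stays unreadable. None of them touches this chain, so none sets a size for the new change, and no step beyond the scatter is expected in this assay. That expectation rests on compound 1 with its limit of > 50000 nM. The expected result is a number no higher from compound 1 to compound 4 (the limit leaves the size open). Compound 4 is estimated at 50000 nM, with an expected range from 15000 nM to 100000 nM.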

Compound 4, half-maximal inhibitory concentration: 34000 nM
For compound 4 the middle estimate is 1.5-fold (0.17 log units) above the measured one, within the range that was stated.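

In this assay, the change from isopropyl to sec-butyl gives an at least 1.4-fold lower number from compound 1 to compound 4 (0.16 log units; that floor lies within the scatter), the only step shown that touches this saturated chain rather than the aromatic group on the nitrogen. Its floor lies within the scatter, so it does not establish a real gain, but the true step could be larger, and compound 4 does give a measured value on the bromophenyl series. The size stays open, as the starting point of the step is a limit and not a number: the limit of > 50000 nM in this assay, at which 2 of the 4 values shown sit.

The compounds shown leave open whether the same methyl would change anything on the 3-(trifluoromethyl)phenyl background of compound 3. They also leave open how a longer chain, a phenyl ring or an amine would read at this position.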